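A few compounds are considered here, and "the series" means these few. Any claim that something is new, unique, unknown or untested is made for them only; others in the source may bear on it.

In a functional assay on MCF7 cells (Homo sapiens) for antiproliferative activity, read by sulforhodamine B assay, with a stated time of 72 h (a lower number here means a stronger inhibitor, a higher number a weaker inhibitor), compound 1 `O=C(/C=C/c1csc2ccccc12)c1ccccc1O` gives 6600 nM. Compound 3 `Cc1ccc(O)c(C(=O)/C=C/c2csc3ccccc23)c1` gives 7800 nM, so compound 1 and compound 3 lie within the scatter of each other. Compound 2 `O=C(/C=C/c1csc2ccccc12)c1cc(F)ccc1O` yields no exact number. Its result is a limit of the assay, > 10000 nM.

Compound 4 `COc1ccc(C(=O)/C=C/c2csc3ccccc23)c(O)c1` has not yet been measured. It differs from compound 1 in one place: methoxy in place of hydrogen on an aromatic carbon. In words, this is methoxy in place of hydrogen on an aromatic carbon.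

Two measured steps also replace a hydrogen on an aromatic carbon. With methyl in place of hydrogen, the step is a 1.2-fold higher number from compound 1 to compound 3 (0.07 log units; within the scatter). With fluoro in place of hydrogen, it is an at least 1.5-fold higher number from compound 1 to compound 2 (0.18 log units; that floor lies within the scatter). Neither step shows a change beyond the scatter, so no clear shift in either direction is expected in this assay, although a result given only as a limit remains possible.

The estimated step is a 1.1-fold higher number from compound 1 to compound 4 (0.03 log units; within the scatter).

Compound 4 is expected at about 7000 nM, with an estimated range from 3000 nM to 15000 nM.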

Compound 4, half-maximal inhibitory concentration: 7500 nM
Compound 4: middle estimate off by 1.1-fold (0.03 log units), on the low side; low and high end bracket the measured number.
By their numbers in this assay, from the lowest: compounds 1, 4 and 3 (each within the scatter of the next). At a limit, above all of these: compound 2.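

The methoxy group sits on an aromatic carbon, meta to a hydroxy group and para to a large group, a place where compounds 2 and 3 carry no group. At this place, the step of a 1.1-fold higher number from compound 1 to compound 4 (0.06 log units; within the scatter) in this assay shows that adding 2 heavy atoms and 1 hydrogen-bond acceptor brings no clear shift in either direction. Compound 2 adds no exact comparison, since its result is a limit of the assay and not a number: the limit of > 10000 nM in this assay, at which 1 of the 4 values shown sits.

Going by these compounds, whether this place would respond to a different kind of group remains open, for example an amine, a carboxylic acid or a longer chain. A single methoxy group also cannot show whether any group here could lower the number beyond the scatter.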